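A few compounds are considered here, and "the series" means these few. Any claim that something is new, unique, unknown or untested is made for them only; others in the source may bear on it.

Measured in an ADME assay on BJ cells (Homo sapiens) for cytotoxicity, with a stated time of 72 h; on this read-out higher numbers stand for an effect only at larger amounts of compound and lower numbers for an effect already at smaller amounts:
- Compound 1 `Cc1cc(NC(=O)Nc2cccc(C(N)=O)c2)c2ccccc2n1`: > 25000 nM, a limit
- Compound 2 `COc1ccc(NC(=O)Nc2cc(C)nc3ccccc23)cc1OC`: > 25000 nM, a limit

Compound 2 gives no exact number, only the limit > 25000 nM. The picture so far is the limit of > 25000 nM in this assay, at which 2 of the 2 values shown sit. Compound 3 `COc1ccc(NC(=O)Nc2cc(C)nc3ccccc23)cc1F` has fluoro in place of methoxy on an aromatic carbon, ortho to a methoxy group and meta to a large group: fluoro in place of methoxy on an aromatic carbon. No measured step sizes this change. With compound 2 at the limit > 25000 nM, the expected step in this assay is none beyond the scatter, in neither direction, and another limit is likely. The estimated step of a number no higher from compound 2 to compound 3 (the limit leaves the size open) stays within that scatter. The estimate for compound 3 is 25000 nM, with an expected range of 10000 nM to 50000 nM.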

Compound 3, half-maximal effective concentration: 26000 nM
Compound 3: the middle estimate sits 1.0-fold (0.02 log units) below what was measured; measured number inside the range.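

For the compounds shown here, the value of compound 2 is only a limit, > 25000 nM, so no step from compound 2 to compound 3 can be read. The compounds shown leave open what fluoro in place of methoxy does in this assay.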